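Working notes on cytotoxicity in the amide series

The source may report more compounds than this note shows. Statements on the series, on what has been measured and on what is new or still open speak of the compounds shown alone.

Compound 1 `CN(Cc1ccccc1)C(=O)c1nc(Cc2ccccc2C(F)(F)F)n(C)c(=O)c1O` is the reference point of this set. In an ADME assay on HepG2 cells (Homo sapiens) for cytotoxicity, in the presence of a further agent that is not named here (on this read-out higher numbers stand for weaker inhibition and lower numbers for stronger inhibition), compound 1 gives > 100000 nM, which is a limit of the assay rather than a number. Compound 2 `COc1c(C(=O)NCc2ccccc2)nc(Cc2ccccc2C(F)(F)F)n(C)c1=O` gives > 100000 nM in this assay, again only a limit. Compound 3 `Cn1c(Cc2ccccc2)nc(C(=O)NCc2ccccc2)c(O)c1=O` gives > 100000 nM in this assay, also a limit. Compound 1 therefore stands where every measured value in this set stands, as recorded in the limit of > 100000 nM in this assay, at which 3 of the 3 values shown sit. Among the compounds with values here, no two measured compounds differ in a single place, so no measured step is available to calibrate the effect of a substituent change.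

Compound 4 `Cn1c(Cc2ccccc2C(F)(F)F)nc(C(=O)NCc2ccccc2F)c(O)c1=O` has not yet been tested in this assay. It differs from compound 1 by (2-fluorobenzyl)amino in place of benzyl(methyl)amino on a carbonyl carbon. With all measured compounds sitting at the limit, no shift beyond the scatter is expected for the step of a number no higher from compound 1 to compound 4 (the limit leaves the size open). Compound 4 is expected to give 100000 nM in this assay, within 40000 nM to 300000 nM, and most probably to be reported once more only as a limit.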

Compound 4, half-maximal inhibitory concentration: > 100000 nM
Compound 4: a limit, no number; the forecaster's own chance of this, stated with the estimate: 85%; the middle value lies on the limit itself.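

Compound 1 and compound 4 are each recorded only as a limit in this assay, so no step can be read between them: the limit of > 100000 nM in this assay, at which 4 of the 4 values shown sit.

The compounds shown leave open whether (2-fluorobenzyl)amino and benzyl(methyl)amino on a carbonyl carbon differ at all in this assay.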